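The source may report more compounds than this note shows. Statements on the series, on what has been measured and on what is new or still open speak of the compounds shown alone.

Working notes on the series in an ADME assay on cells (Astrocyte, Rattus norvegicus, strain Wistar) for inhibition, read by sulforhodamine B assay, with a stated time of 72 h; a lower number here means that less compound is tolerated, a higher number that more compound is tolerated. Of the compounds shown here, two have numbers so far: compound 1 (`CCC(=O)Oc1cccc2ccc(/C=C/c3ccccc3[N+](=O)[O-])nc12`) gives 55200 nM, and compound 2 (`O=C(/C=C/c1ccc([N+](=O)[O-])o1)c1ccc(Br)cc1`) gives 85400 nM. These two values lie within the usual scatter of each other, so compound 2 stands level with compound 1 on the numbers shown, and the two alone show no trend.

The next case is compound 3 (`O=C(/C=C/c1ccc([N+](=O)[O-])o1)c1ccc(I)cc1`), which departs from compound 2 at one place: iodo in place of bromo on an aromatic carbon. In words, this is iodo in place of bromo on an aromatic carbon, para to a large group. Going by the values given here, no measured pair shows a change of this kind, so the expectation rests only on the value of compound 2 at 85400 nM and the small size of the change. The expected outcome is no shift beyond the scatter in this assay, with no favoured direction. The estimated move is a 1.1-fold lower number from compound 2 to compound 3 (0.04 log units; within the scatter). Compound 3 is expected at 78000 nM, with an estimated range of 38000 nM to 160000 nM.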

Compound 3, half-maximal cytotoxic concentration: 68200 nM
Estimate against measurement, compound 3: 1.1-fold (0.06 log units) above, within the range that was stated.
By their numbers in this assay, from the lowest: compounds 1, 3 and 2 (each within the scatter of the next).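

The step for iodo in place of bromo on an aromatic carbon, para to a large group, is a 1.3-fold lower number from compound 2 to compound 3 (0.10 log units; within the scatter) in this assay and gives the series its first pair that differs in one place. At this position, the two halogens stand level on the numbers, so this exchange gives no measurable separation between compound 2 and compound 3. Nothing measured here offers an explanation for this result.

On these data alone, only bromo and iodo are compared at this place, so the effect of an amine or a carboxylic acid there remains open. The compounds shown also leave open how the nitro group on the shared core of compound 2 and compound 3 bears on the number, as no pair shown changes it.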